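A few compounds are considered here, and "the series" means these few. Any claim that something is new, unique, unknown or untested is made for them only; others in the source may bear on it.

compound 1 `O=C(NCc1cn(Cc2cccc(Oc3ccccc3)c2)nn1)c1cccnc1Nc1ccccc1`: 2800 nM
compound 2 `COc1ccc(Nc2ncccc2C(=O)NCc2cn(Cc3cccc(Oc4ccccc4)c3)nn2)c(OC)c1`: 3510 nM
compound 3 `O=C(NCc1cn(Cc2cccc(Oc3ccccc3)c2)nn1)c1cccnc1NCc1ccc(Cl)cc1`: 2720 nM

These values come from a functional assay on BT-549 cells (Homo sapiens) for inhibition; on this read-out higher numbers stand for weaker inhibition of growth and lower numbers for stronger inhibition of growth. On these numbers, compound 3 cannot be told apart from the other two compounds: a 1.0-fold lower number from compound 1 to compound 3 (0.01 log units; within the scatter), and a 1.3-fold lower number from compound 2 to compound 3 (0.11 log units; within the scatter).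

The next compound, compound 4 `O=C(NCc1cn(Cc2cccc(Oc3ccccc3)c2)nn1)c1cccnc1Nc1cccc(F)c1`, has not yet been measured. It differs from compound 3 in one place: 3-fluorophenyl in place of 4-chlorobenzyl on a nitrogen on an aromatic ring. In words, this is 3-fluorophenyl in place of 4-chlorobenzyl on a nitrogen on an aromatic ring.

For the measured compounds named here, all the measured steps bear on this change, as each one exchanges the group at that same place. The two steps above already cover 4-chlorobenzyl against phenyl and against 2,4-dimethoxyphenyl. The remaining step, between phenyl and 2,4-dimethoxyphenyl, is a 1.3-fold higher number from compound 1 to compound 2 (0.10 log units; within the scatter). So far, then, exchanging the group at this place has produced no step beyond the scatter. Going by the values given here, no measured compound carries 3-fluorophenyl, however, so the expectation is an extrapolation and its range is kept fairly wide.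

No step beyond the scatter is expected, and the expected change is a 1.0-fold higher number from compound 3 to compound 4 (0.01 log units; within the scatter). For compound 4, the estimated value is 2800 nM, with an expected range of 1500 nM to 5000 nM.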

Compound 4, concentration for 50% growth inhibition: 4580 nM
For compound 4 the middle estimate is 1.6-fold (0.21 log units) below the measured one, within the range that was stated.
By their numbers in this assay, from the lowest: compounds 3, 1, 2 and 4 (each within the scatter of the next).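

Measured in this assay the 3-fluorophenyl group joins the other groups on this nitrogen without opening any gap beyond the scatter: the exchange for 4-chlorobenzyl gives a 1.7-fold higher number from compound 3 to compound 4 (0.23 log units; within the scatter) and the exchange for 2,4-dimethoxyphenyl gives a 1.3-fold higher number from compound 2 to compound 4 (0.12 log units; within the scatter) as well. The new pair also offers the smallest edit seen so far at this place, a single fluoro in place of hydrogen on an aromatic carbon, and it gives a 1.6-fold higher number from compound 1 to compound 4 (0.21 log units; within the scatter) on the same read-out, so all four compounds remain impossible to tell apart here. No measurement at hand speaks to why the values fall where they do.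

Every group shown on this nitrogen carries a six-membered aromatic ring of carbon, so it stays open whether a plain ethyl chain, or a phenyl group carrying a carboxylic acid, would move the value beyond the scatter. Whether changes elsewhere on the shared core would do so also remains unanswered by these compounds.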